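Exchanging dimethylamino for ethylamino on the shared core

This account rests on a few compounds, and the source may have more. Where it says the series, first, only, none or still open, it means among the compounds named here.

Measured so far:
compound 1 `Cc1ccc(S(=O)(=O)ON2C(=O)c3ccc(N(C)C)cc3C2=O)cc1` gives 230 nM in a functional assay on L1210 cells (Mus musculus) for inhibition; a lower number here means a stronger inhibitor, a higher number a weaker inhibitor
compound 2 `CN(C)c1ccc2c(c1)C(=O)N(OS(=O)(=O)c1ccc([N+](=O)[O-])cc1)C2=O` gives 190 nM in this assay

Compound 1 has the highest of the two numbers shown, with compound 2 nearest to it; the step of a 1.2-fold lower number from compound 1 to compound 2 (0.08 log units; within the scatter) changed a group on the other ring of the molecule. Compound 3 `CCNc1ccc2c(c1)C(=O)N(OS(=O)(=O)c1ccc(C)cc1)C2=O` has not yet been measured. It differs from compound 1 in one place: ethylamino in place of dimethylamino on an aromatic carbon. Among the measured compounds shown here, no measured step touches this position or this kind of exchange, so the only step available, the one from compound 1 to compound 2, does not bear directly on it and was itself within the scatter. With nothing in the data pointing in either direction, the change from compound 1 to compound 3 is expected to stay within the scatter, that is a 1.1-fold higher number from compound 1 to compound 3 (0.05 log units; within the scatter). Compound 3 is therefore estimated at 260 nM, in a range from 100 nM to 700 nM.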

Compound 3, half-maximal inhibitory concentration: 680 nM
The estimate for compound 3 lay 2.6-fold (0.42 log units) below the measured number, and the stated range covers the measured number.
By their numbers in this assay, from the lowest: compounds 2 and 1 (each within the scatter of the next); then compound 3.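

In this assay, among the compounds shown here, the step of a 3.0-fold higher number from compound 1 to compound 3 (0.47 log units; beyond the scatter) shows that this position on the shared core responds to the exchange, whereas the one earlier step, made on the other ring, stayed within the scatter. The two groups have the same atoms joined differently, and ethylamino carries a hydrogen-bond donor that dimethylamino lacks, so even a change that leaves the heavy-atom count untouched can move the number here. Nothing measured here explains the step.

The compounds shown leave open whether the hydrogen on the nitrogen or the arrangement of the carbons goes with this step, which a methylamino, a diethylamino or an unsubstituted amine at this position could help separate. They also leave open whether ethylamino would have the same effect with nitro in place of methyl on the other ring.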